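The compounds below may be only part of what the source reports. "The series", "measured", "known", "first", "only" and "open" are said of these compounds alone.

The shared core is unsubstituted on its ring nitrogen in compound 1 `NC(=O)c1c(NC(=O)c2ccccc2Cl)sc2c1CCNC2`, which in a functional assay on HL-60 cells (Homo sapiens) for antiproliferative activity, with a stated time of 24 h (a lower number here means a stronger inhibitor, a higher number a weaker inhibitor), gives 18600 nM. Compound 2 `NC(=O)c1c(NC(=O)c2ccccc2Cl)sc2c1CCN(C(=S)Nc1cccc3ccccc13)C2` carries a larger group on that nitrogen and gives 13400 nM in this assay. Compound 3 `NC(=O)c1c(NC(=O)c2ccccc2Cl)sc2c1CCN(C(=O)Nc1ccccc1Cl)C2` gives 12500 nM in this assay, and there is a 1.5-fold lower number from compound 1 to compound 3 (0.17 log units; within the scatter). Compound 3 thus has the lowest of the three numbers, but its gaps to compound 2 and to compound 1 both fall within the scatter, so none of the three can be set apart from the others. Compound 4 `NC(=O)c1c(NC(=O)c2ccccc2Cl)sc2c1CCN(C(=S)Nc1ccccc1Br)C2` is not yet measured; it differs from compound 3 by a group of 10 heavy atoms (7 carbon, 1 nitrogen, 1 sulfur, 1 bromine; one six-membered aromatic ring of carbon only) in place of a group of 10 heavy atoms (7 carbon, 1 nitrogen, 1 oxygen, 1 chlorine; one six-membered aromatic ring of carbon only), on an amine nitrogen in a ring. Among the measured compounds shown here, only the step from compound 1 to compound 3 bears directly on this place, and it stayed within the scatter; compound 2, which also has sulfur in its group on this nitrogen, gives a number close to that of compound 3. Compound 4 is therefore expected to show a 1.0-fold lower number from compound 3 to compound 4 (0.02 log units; within the scatter), nothing beyond the scatter. The estimate for compound 4 in this assay is 12000 nM, within a range from 5000 nM to 30000 nM.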

Compound 4, half-maximal inhibitory concentration: 9090 nM
The estimate for compound 4 lay 1.3-fold (0.12 log units) above the measured number; measured number inside the range.
By their numbers in this assay, from the lowest: compounds 4, 3, 2 and 1 (each within the scatter of the next, the first and the last beyond it).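

In this assay, among the compounds shown here, a group on the amine nitrogen in a ring now gives a 2.0-fold lower number from compound 1 to compound 4 (0.31 log units; beyond the scatter), the first step at this place to pass the scatter, though only modestly. The groups themselves remain unseparated: sulfur and bromine entering for oxygen and chlorine gives a 1.4-fold lower number from compound 3 to compound 4 (0.14 log units; within the scatter), and 2-bromophenyl in place of naphthalen-1-yl on an amide-type nitrogen gives a 1.5-fold lower number from compound 2 to compound 4 (0.17 log units; within the scatter). No measurement offered here accounts for these numbers.

From the compounds shown here alone, compound 3 and compound 4 differ in both pairs of atoms at once, so the share of the sulfur and that of the bromine stay open. Also open, going by these compounds, is how this assay would respond to a plain alkyl chain in place of the aromatic ring, or to a carboxylic acid on that ring.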